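Trifluoromethyl to Methoxy in an Antiproliferative Series

This account rests on a few compounds, and the source may have more. Where it says the series, first, only, none or still open, it means among the compounds named here.

Compound 1 `COc1ccc(NC(=O)c2cc(=O)[nH]c3cc(Br)ccc23)cc1`: > 20000 nM, a limit of the assay
Compound 2 `O=C(Nc1ccc(C(F)(F)F)cc1)c1cc(=O)[nH]c2cc(Br)ccc12`: > 20000 nM, a limit of the assay
Compound 3 `O=C(Nc1cc(F)cc(F)c1)c1cc(=O)[nH]c2cc(C(F)(F)F)ccc12`: 14200 nM

In a functional assay on KYSE-70 cells for antiproliferative activity against KYSE-70 cell line (Homo sapiens), read by MTT assay, with a stated time of 72 h (a lower number here means a stronger inhibitor, a higher number a weaker inhibitor), compound 1 sits at a limit. Compound 2 likewise sits at a limit. The step that the two limits leave unreadable from compound 2 to compound 1, the change (methoxy in place of trifluoromethyl on an aromatic carbon), is therefore unreadable because of the limit of > 20000 nM in this assay, at which 2 of the 3 values shown sit. Within the data shown here, compound 3 is the only one with a number. The difference between the cores of compound 2 and compound 3 is not broken down here. Compound 4 `COc1ccc2c(C(=O)Nc3cc(F)cc(F)c3)cc(=O)[nH]c2c1` arises from compound 3 by methoxy in place of trifluoromethyl on an aromatic carbon; the place differs from the earlier one, so this is the same kind of change, not the same. With the measured step unreadable, compound 4 is expected to stay near compound 3, whose value is 14200 nM, with an expected step of a 1.4-fold higher number from compound 3 to compound 4 (0.15 log units; within the scatter). The estimate for compound 4 is 20000 nM, between 7000 nM and 60000 nM.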

Compound 4, half-maximal inhibitory concentration: > 20000 nM
Compound 4 was reported as a limit; the forecaster's own chance of this, stated with the estimate: 55%; the middle value sits exactly at the limit.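

In this assay, going by these compounds, methoxy in place of trifluoromethyl on the core of compound 3 gives an at least 1.4-fold higher number from compound 3 to compound 4 (0.14 log units; that floor lies within the scatter), so the one floor that can be read stays within the scatter, and the true size of the step remains unknown. Compound 4 gives > 20000 nM, which is a limit and not a number. The same kind of change on the core of compound 2 cannot be read, so the two cores cannot be compared and nothing shows whether the change carries from one to the other: the limit of > 20000 nM in this assay, at which 3 of the 4 values shown sit.

On these data alone, whether an amine or a carboxylic acid in place of trifluoromethyl on the core of compound 3 would give a number remains open. So does the effect of a longer chain there.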